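Fluoro in Place of Methoxy on a Second Core

The source may hold more compounds than are shown below. What is called first, only, known or untested is meant among the compounds shown, and "the series" means these compounds.

Of the compounds shown here, three have been measured in a functional assay on MCF7 cells (Homo sapiens) for inhibition, read by sulforhodamine B assay, with a stated time of 72 h; on this read-out lower numbers stand for stronger inhibition and higher numbers for weaker inhibition. Compound 1 `COc1ccc2cc(C(C)c3nnc4n3N=C(c3ccc(F)cc3)CS4)ccc2c1` gives 15800 nM. Compound 2 `COc1ccc(C2=Nn3c(nnc3C(C)c3ccc4cc(OC)ccc4c3)SC2)cc1` gives 6600 nM. Compound 3 `COc1ccc(C2=Nn3c(nnc3C(C)c3ccc(CC(C)C)cc3)SC2)cc1` gives 5200 nM, which lies within the scatter of the value of compound 2. The difference between the cores of compound 2 and compound 3 is not broken down here. Compound 2 and compound 1 differ by fluoro in place of methoxy on an aromatic carbon, a change that produced a 2.4-fold higher number from compound 2 to compound 1 (0.38 log units; beyond the scatter).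

Compound 4 `CC(C)Cc1ccc(C(C)c2nnc3n2N=C(c2ccc(F)cc2)CS3)cc1` has not yet been measured. It differs from compound 3 by fluoro in place of methoxy on an aromatic carbon, the same change made on the core of compound 3. A step of similar size is expected in this assay, since on the other core this change gave a 2.4-fold higher number from compound 2 to compound 1 (0.38 log units; beyond the scatter). Compound 4 is therefore estimated at 12000 nM, expected to fall between 5000 nM and 30000 nM, which corresponds to an expected 2.3-fold higher number from compound 3 to compound 4 (0.36 log units; beyond the scatter).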

Compound 4, half-maximal inhibitory concentration: 8900 nM
For compound 4 the middle estimate is 1.3-fold (0.13 log units) above the measured one, within the range that was stated.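

In this assay, fluoro in place of methoxy on an aromatic carbon gave a 1.7-fold higher number from compound 3 to compound 4 (0.23 log units; within the scatter), so on this core the step alone stays within the scatter. Set beside the earlier step, the two do not differ beyond what repeated measurements allow: the same change on two cores in this assay, a 2.4-fold higher number (0.38 log units; beyond the scatter) from compound 2 to compound 1 and a 1.7-fold higher number (0.23 log units; within the scatter) from compound 3 to compound 4, 1.4-fold (0.15 log units) apart, within the scatter of two such steps. Within the data shown here, this shows that the change carried from one core to the other without a detectable difference in size, but it rests on only two pairs and does not show that the step would hold on any further core.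

The compounds shown leave open how a chloro, a hydroxyl or an amine in the same place would compare. They also leave open whether these groups would behave alike on both cores.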